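From 4-(trifluoromethoxy)benzyl to 2-methoxybenzyl at the ether

The compounds below may be only part of what the source reports. "The series", "measured", "known", "first", "only" and "open" are said of these compounds alone.

Compound 3 `CC(C)(N)C(=O)N[C@H](COCc1ccc(OC(F)(F)F)cc1)c1nnnn1CCOC(=O)NCCCCO` gives 33.2 nM in a functional assay on cells for inhibition of growth hormone secretagogue receptor type 1 (Homo sapiens), read by FLIPR and calcium flux (on this read-out higher numbers stand for an effect only at larger amounts of compound and lower numbers for an effect already at smaller amounts), the highest of the three numbers: compound 1 `CC(C)(N)C(=O)N[C@H](COCc1cccc(C(F)(F)F)c1)c1nnnn1CCOC(=O)NCCCCO` gives 1.79 nM and compound 2 `CC(C)(N)C(=O)N[C@H](COCc1cccc(OC(F)(F)F)c1)c1nnnn1CCOC(=O)NCCCCO` gives 3.1 nM. Compound 4 `COc1ccccc1COC[C@@H](NC(=O)C(C)(C)N)c1nnnn1CCOC(=O)NCCCCO` carries 2-methoxyphenyl in place of 4-(trifluoromethoxy)phenyl on a saturated chain carbon bound to an oxygen on a saturated carbon. Within the data shown here, no measured step touches a 2-methoxyphenyl, but two steps show how strongly the benzyl part matters: a 19-fold higher number from compound 1 to compound 3 (1.27 log units; beyond the scatter) and an 11-fold higher number from compound 2 to compound 3 (1.03 log units; beyond the scatter) are both large and beyond the scatter, while a 1.7-fold higher number from compound 1 to compound 2 (0.24 log units; within the scatter) stays within it. Because compound 3 sits at 33.2 nM after such moves, another change of the substituent is expected to shift this assay again, more likely toward lower numbers, though the direction is uncertain. The expected step is a 2.8-fold lower number from compound 3 to compound 4 (0.44 log units; beyond the scatter). Compound 4 is therefore estimated near 12 nM, within 2 nM to 70 nM.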

Compound 4, half-maximal effective concentration: 1.11 nM
Beside the measured number, compound 4's estimate is 11-fold (1.03 log units) above it; the measured number lies below the stated range.
By their numbers in this assay, from the lowest: compounds 4, 1 and 2 (each within the scatter of the next, the first and the last beyond it); then compound 3.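

In this assay the change to 2-methoxyphenyl gives a 30-fold lower number from compound 3 to compound 4 (1.48 log units; beyond the scatter) and so reverses the large loss seen with 4-(trifluoromethoxy)phenyl, showing that this position needs no fluorine-bearing group among the compounds shown. The same group gives a 2.8-fold lower number from compound 2 to compound 4 (0.45 log units; beyond the scatter) and also a 1.6-fold lower number from compound 1 to compound 4 (0.21 log units; within the scatter), the latter step staying within the scatter. Nothing given here explains these shifts. Still open, from the compounds shown here alone, is how an unsubstituted phenyl or a pyridine ring would read at this place, so the part played by the methoxy group itself remains unsettled.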